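A few compounds are considered here, and "the series" means these few. Any claim that something is new, unique, unknown or untested is made for them only; others in the source may bear on it.

Working notes on the series. Compound 1 `Cc1nc(C(NC(=O)C(=O)Nc2ccc(C(F)(F)F)cc2)C2CCCCN2)sc1CO`, compound 2 `CC(=O)c1ccc(NC(=O)C(=O)NC(c2nc(C)c(CCO)s2)C2CCCCN2)cc1` and compound 3 `Cc1ccc(NC(=O)C(=O)NC(c2nc(C)c(CO)s2)C2CCCCN2)cc1F` share one core and differ in the group on the amide-type nitrogen and in the side chain on the shared core.

In an ADME assay on TZM-b1 cells (Homo sapiens) for cytotoxicity, read by XTT assay, with a stated time of 3 days (a lower number here means that less compound is tolerated, a higher number that more compound is tolerated), compound 1 gives > 75500 nM, which is a limit of the assay. In this assay compound 2 gives > 77300 nM, also a limit. In this assay compound 3 gives > 88000 nM, again a limit. Compound 2 thus stands at a limit, as do the other two values shown (the limit of > 75500 nM in this assay, at which 1 of the 3 values shown sits, (the limit of > 77300 nM in this assay, at which 1 of the 3 values shown sits), (the limit of > 88000 nM in this assay, at which 1 of the 3 values shown sits)). Going by the values given here, the single step between compounds differing in one place, a step that the two limits leave unreadable from compound 1 to compound 3, cannot be read: both ends are limits.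

Compound 4 `Cc1nc(C(NC(=O)C(=O)Nc2ccc(Cl)cc2)C2CCCCN2)sc1CCO` differs from compound 2 by chloro in place of acetyl on an aromatic carbon. Among the compounds with values here, no readable measured step bears on this change, and every value in this assay so far is a limit. The expected step is a step that the limit leaves unreadable from compound 2 to compound 4, nothing beyond the scatter. Compound 4 is expected to sit at 80000 nM in this assay, within 40000 nM to 160000 nM, most likely again reported only as a limit.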

Compound 4, half-maximal cytotoxic concentration: 32800 nM
Beside the measured number, compound 4's estimate is 2.4-fold (0.39 log units) above it; measured number below the stated range.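

Chloro in place of acetyl on an aromatic carbon, para to a large group, gives an at least 2.3-fold lower number from compound 2 to compound 4 (0.37 log units; beyond the scatter) in this assay, so less compound is tolerated with the 4-chlorophenyl group than with the 4-acetylphenyl group. Compound 2 stands at a limit, so the size of this step is a floor only: the limit of > 77300 nM in this assay, at which 1 of the 4 values shown sits. This is the only readable value among the compounds shown, and it establishes that a change at this position can move the read-out, which the limits of the earlier compounds could not show.

On these data alone, whether the lower number follows from the arrival of chloro or the loss of acetyl stays open, as does whether it would hold with the shorter side chain of compound 1 and compound 3. A carboxylic acid, an amine or a methoxy group at this position would help to separate these readings.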